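The source may report more compounds than this note shows. Statements on the series, on what has been measured and on what is new or still open speak of the compounds shown alone.

Measured compounds:
- compound 1 `COc1ccc2c(c1)OC(COc1ccc(CCC(=O)O)c(F)c1)CO2`: 80%
- compound 2 `Cn1ccnc1C(CC(=O)O)c1ccc(OCC2COc3ccc(Cl)cc3O2)cc1`: 68%
- compound 3 `CC#C[C@@H](CC(=O)O)c1ccc(OC[C@H]2COc3ccc(F)cc3O2)cc1`: 86%

In a functional assay on HEK293 cells for agonist activity at Free fatty acid receptor 1 (Homo sapiens), read by fluorescence and calcium flux, with a stated time of 10 min (on this read-out higher numbers stand for larger maximal responses and lower numbers for smaller maximal responses), compound 3 gives 86%, the highest of the three numbers. Compound 1 gives 80%, a number that lies within the scatter of compound 3, so no order between these two can be claimed. Compound 2 gives 68%, a number that lies beyond the scatter below compound 3.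

The step under consideration leads from compound 3 to compound 4 `CC#C[C@@H](CC(=O)O)c1ccc(OC[C@H]2COc3ccc(OC(F)(F)F)cc3O2)cc1`. The change is trifluoromethoxy in place of fluoro on an aromatic carbon. Among the compounds with values here, no pair of measured compounds differs by a change of this kind, so there is no measured step to lean on; the three measured compounds do show that maximal responses stay within a fairly narrow band. On that basis the step from compound 3 to compound 4 a number 6 percentage points lower from compound 3 to compound 4 (within the scatter) is expected to be small, most likely not beyond the scatter, with a slight lean downward. Compound 4 is therefore estimated at 80%, with a range from 62% to 98%.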

Compound 4, largest response reached (Emax), in percent of the reference or control that the assay uses: 73%
Estimate against measurement, compound 4: 7 percentage points above; low and high end bracket the measured number.
By their numbers in this assay, from the lowest: compounds 2, 4, 1 and 3 (each within the scatter of the next, the first and the last beyond it).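

In this assay, trifluoromethoxy in place of fluoro on an aromatic carbon of the shared core gives a number 13 percentage points lower from compound 3 to compound 4 (beyond the scatter). Within the data shown here, this is the first step that isolates a single change, and it shows that the group at this place on the six-membered aromatic ring can shift the maximal response by more than the scatter, while compound 4 still reaches 73%. Nothing measured here bears on why the response shifts with this change.

The compounds shown leave open whether the oxygen or the fluorine atoms of the entering group account for the step, and trifluoromethyl on the same aromatic carbon would separate the two. As far as these compounds go, whether a nitrile or an amine at this place would keep the response of compound 3 also remains open.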